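This account rests on a few compounds, and the source may have more. Where it says the series, first, only, none or still open, it means among the compounds named here.

Among the measured compounds shown here, compound 3 `Cc1cc(C)cc(S(=O)(=O)c2c(C(=O)NC3CN(Cc4cccnc4)C3)[nH]c3ccc(Cl)cc23)c1` is the one compound here that yields an actual number in an ADME assay on MT4 cells (Homo sapiens) for cytotoxicity, read by MTT assay, with a stated time of 5 days; on this read-out higher numbers stand for lower toxicity in this test and lower numbers for higher toxicity in this test: compound 3 gives 36000 nM. Compound 1 `Cc1cc(C)cc(S(=O)(=O)c2c(C(=O)N[C@@H]3CCN(Cc4ccccc4F)C3)[nH]c3ccc(Cl)cc23)c1` gives only a limit of the assay in this assay, namely > 231000 nM. Compound 2 `Cc1cc(C)cc(S(=O)(=O)c2c(C(=O)N[C@@H]3CCN(Cc4ccccc4C#N)C3)[nH]c3ccc(Cl)cc23)c1` likewise gives only a limit of the assay in this assay, namely >= 186000 nM. For the measured compounds named here, the single measured step, a step that the two limits leave unreadable from compound 1 to compound 2, is thus of a size the two limits leave unreadable, and it alters a substituent on an aromatic carbon rather than the amide-type nitrogen. Compound 4 `Cc1cc(C)cc(S(=O)(=O)c2c(C(=O)NS(=O)(=O)c3ccccc3)[nH]c3ccc(Cl)cc23)c1` differs from compound 3 by phenylsulfonyl in place of 1-((pyridin-3-yl)methyl)azetidin-3-yl on an amide-type nitrogen. No measured step touches that nitrogen, so the numbers shown set neither the size nor the direction of this change, and the scatter of the assay is the only guide. The estimate for compound 4 in this assay is 90000 nM, with a range from 25000 nM to 250000 nM. The step that this estimate implies is a 2.5-fold higher number from compound 3 to compound 4 (0.40 log units; beyond the scatter).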

Compound 4, half-maximal cytotoxic concentration: 167000 nM
Beside the measured number, compound 4's estimate is 1.9-fold (0.27 log units) below it; measured number inside the range.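

Among the compounds shown here, at the amide-type nitrogen, this assay now gives a step that can be read, whereas the only earlier step, made on an aromatic carbon, was hidden by two limits: phenylsulfonyl in place of 1-((pyridin-3-yl)methyl)azetidin-3-yl gives a 4.6-fold higher number from compound 3 to compound 4 (0.67 log units; beyond the scatter). A higher number here means lower toxicity in this test, so this one swap at this nitrogen moves the result in that direction by more than the usual scatter. Nothing measured here bears on why the number rises.

Going by these compounds, the swap replaces a whole group at once, so it remains open whether the sulfonyl part, the phenyl ring or the loss of the original group accounts for the step. A benzoyl or methylsulfonyl group on the same nitrogen would help separate these parts.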